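The source may report more compounds than this note shows. Statements on the series, on what has been measured and on what is new or still open speak of the compounds shown alone.

Values so far in a physicochemical assay for lipophilicity, at pH 7.4; a higher number here means a more lipophilic compound, a lower number a more polar compound

compound 1 `O=C(NC1CC1)C1CCN(c2cnccc2-c2ccccn2)CC1` gives 1.3
compound 2 `O=C(NC1CC1)C1CCN(c2cncnc2-c2ccccc2)CC1` gives 1.8
compound 3 `CNC(=O)C1CCN(c2cncnc2-c2ccccc2)CC1` gives 1.4

In this assay compound 3 lies within the scatter of compound 1 and beyond the scatter under compound 2. The next compound is compound 4 `CCNC(=O)C1CCN(c2cncnc2-c2ccccc2)CC1`, which turns the methylcarbamoyl of compound 3 into ethylcarbamoyl: methyl in place of hydrogen on a saturated chain carbon bound to an amide-type nitrogen.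

Among the measured compounds shown here, only one measured step bears on this change. It is a number 0.40 log units lower from compound 2 to compound 3 (beyond the scatter), with methyl in place of cyclopropyl on an amide-type nitrogen. That step is modest and beyond the scatter, but it is a single pair, and no ethyl amide has been measured yet. Going from methyl to ethyl runs opposite to that step, so part of it is expected back, in the upward direction. The expected step is a number 0.20 log units higher from compound 3 to compound 4 (within the scatter), small and possibly not beyond the scatter. The estimate for compound 4 is 1.6 with an expected range from 1.3 to 1.9.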

Compound 4, distribution coefficient: 1.8
Compound 4: middle estimate off by 0.20 log units, on the low side; the measured number falls inside the stated range.
By their numbers in this assay, from the lowest: compounds 1 and 3 (each within the scatter of the next); then compounds 2 and 4 (each within the scatter of the next).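

Methyl in place of hydrogen on a saturated chain carbon bound to an amide-type nitrogen gives a step in this assay that lies beyond the scatter (a number 0.40 log units higher from compound 3 to compound 4 (beyond the scatter)), so this position now has a measured response to a change on the chain itself. Ethyl in place of cyclopropyl on the amide-type nitrogen does not separate the two compounds (no change at the digits printed from compound 2 to compound 4 (within the scatter)), which leaves the methyl amide, compound 3, apart from both on this shared core. Nothing measured here explains why the ethyl and cyclopropyl amides read alike.

Still open, from the compounds shown here alone, is how a longer chain such as propyl, or a branched isopropyl, would read on the same amide-type nitrogen. Also open, going by these compounds, is whether ethyl and cyclopropyl read alike on the core of compound 1.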